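A Third Methoxy Group Against Two: An Expected Outcome

A few compounds are considered here, and "the series" means these few. Any claim that something is new, unique, unknown or untested is made for them only; others in the source may bear on it.

Compound 1 `COc1cc(Nc2nc(SCc3ccc(C(F)(F)F)cc3)nc3ccccc23)cc(OC)c1`: > 50000 nM
Compound 2 `COc1ccc(Nc2nc(SCc3ccc(C(F)(F)F)cc3)nc3ccccc23)cc1OC`: 17900 nM

In a functional assay on HGC-27 cells (Homo sapiens) for cytotoxicity, read by MTT assay, with a stated time of 72 h (on this read-out higher numbers stand for weaker inhibition and lower numbers for stronger inhibition), compound 1 reaches only > 50000 nM, which is a limit of the assay rather than a number. In this assay compound 2 gives 17900 nM. Among the measured compounds shown here, compound 2 therefore stands as the only genuine number in the set, the other entry being a limit. For the measured compounds named here, the single measured step, an at least 2.7-fold lower number from compound 1 to compound 2 (0.44 log units; beyond the scatter), rearranged the two methoxy groups on the nitrogen-bound ring, and its size is known only as a floor because the limit of > 50000 nM in this assay, at which 1 of the 2 values shown sits, caps the side of compound 1.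

Compound 3 `COc1cc(Nc2nc(SCc3ccc(C(F)(F)F)cc3)nc3ccccc23)cc(OC)c1OC` differs from compound 2 by methoxy in place of hydrogen on an aromatic carbon. It thus carries both the arrangement of compound 1 and the methoxy that set compound 2 apart. Going by the values given here, the step of an at least 2.7-fold lower number from compound 1 to compound 2 (0.44 log units; beyond the scatter) is the only guide, and it cuts both ways. Compound 3 is expected to land near compound 2 or somewhat higher, the step of a 1.2-fold higher number from compound 2 to compound 3 (0.09 log units; within the scatter) being modest at most. The estimate for compound 3 is 22000 nM, within 7000 nM to 60000 nM.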

Compound 3, half-maximal inhibitory concentration: 14000 nM
For compound 3 the middle estimate is 1.6-fold (0.20 log units) above the measured one; the measured number falls inside the stated range.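

The third methoxy group reads differently depending on the ring that receives it. Added to the ring of compound 2, at a carbon ortho to a methoxy group, it gives a 1.3-fold lower number from compound 2 to compound 3 (0.11 log units; within the scatter) in this assay, so this extra group brings no change that can be told apart from repeat measurements. Added to the ring of compound 1, the same methoxy in place of hydrogen gives an at least 3.5-fold lower number from compound 1 to compound 3 (0.55 log units; beyond the scatter), which shows that this aromatic carbon carries the difference from compound 1 whether or not the other methoxy pattern is kept, and that compound 2 and compound 3, the two with a genuine number, both hold a methoxy there while compound 1 does not; the size of this step is only a floor, since the entry for compound 1 is a limit and not a number: the limit of > 50000 nM in this assay, at which 1 of the 3 values shown sits.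

The compounds shown leave open whether a hydroxyl, an amine or a longer chain such as ethoxy on this aromatic carbon would shift the number beyond the scatter. They also leave open whether the same reading holds once the trifluoromethyl on the other ring gives way to a nitrile or a chlorine.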